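The source may report more compounds than this note shows. Statements on the series, on what has been measured and on what is new or still open speak of the compounds shown alone.

Measured compounds:
compound 1 `CN(C)Cc1ccc2nc(NC(=O)N/N=C/c3cn(Cc4ccccc4Cl)c4ccccc34)sc2c1` — 1600 nM
compound 2 `CCN(CC)Cc1ccc2nc(NC(=O)N/N=C/c3cn(Cc4ccc(C)cc4)c4ccccc34)sc2c1` — 320 nM
compound 3 `CCN(CC)Cc1ccc2nc(NC(=O)N/N=C/c3cn(Cc4ccccc4)c4ccccc34)sc2c1` — 450 nM

In a functional assay on NCI-H460 cells (Homo sapiens) for cytotoxicity, read by MTT assay, with a stated time of 72 h (on this read-out higher numbers stand for weaker inhibition and lower numbers for stronger inhibition), compound 1 gives 1600 nM, the highest of the three numbers. Compound 3 gives 450 nM and compound 2 gives 320 nM, each beyond the scatter from compound 1. Compound 4 `CN(C)Cc1ccc2nc(NC(=O)N/N=C/c3cn(Cc4ccc(Cl)cc4Cl)c4ccccc34)sc2c1` has not been measured; it differs from compound 1 by chloro in place of hydrogen on an aromatic carbon. Going by the values given here, the only measured step, a 1.4-fold higher number from compound 2 to compound 3 (0.15 log units; within the scatter), concerns methyl against hydrogen, a different group, in compounds that also differ from compound 1 elsewhere, and it lies within the scatter. Among the compounds with values here, no measured step sets a chloro against a hydrogen, so the change has no direct precedent. Within the data shown here, with the one available step showing no movement beyond the scatter, a step of at most modest size is expected in this assay, in no firm direction. Compound 4 is therefore expected near 1200 nM, within 450 nM to 3200 nM, the expected step being a 1.3-fold lower number from compound 1 to compound 4 (0.12 log units; within the scatter).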

Compound 4, half-maximal inhibitory concentration: 950 nM
Compound 4: the middle estimate sits 1.3-fold (0.10 log units) above what was measured; measured number inside the range.
By their numbers in this assay, from the lowest: compounds 2 and 3 (each within the scatter of the next); then compounds 4 and 1 (each within the scatter of the next).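

Going from 2-chlorobenzyl to 2,4-dichlorobenzyl gives a 1.7-fold lower number from compound 1 to compound 4 (0.23 log units; within the scatter) in this assay and is the first chloro-for-hydrogen step in the series. A second chloro group can therefore stand on this aromatic carbon, para to a large group and meta to the first chloro group, without movement beyond the scatter in the setting of compound 1. No supporting measurement bears on this result, so the step remains an observation without an assigned cause.

As far as these compounds go, it remains open whether methoxy, an amine or a carboxylic acid on this same carbon would give a step beyond the scatter. From the compounds shown here alone, it is also open whether chloro in place of hydrogen would give a comparable step on the unsubstituted benzyl group of compound 3.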